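Swapping chloro for methyl on the aryl ring of compound 1

A few compounds are considered here, and "the series" means these few. Any claim that something is new, unique, unknown or untested is made for them only; others in the source may bear on it.

Among the compounds with values here, compound 1 `OC[C@@H]1CCCN1c1ncnc2sc(Nc3ccc(Cl)cc3)nc12` gives 629 nM in an assay on CHO cells for displacement of a labelled ligand from adenosine receptor A1 (Homo sapiens), read by scintillation counting, with a stated time of 3 h (on this read-out lower numbers stand for stronger inhibition and higher numbers for weaker inhibition), the only number among the values shown. Compound 2 `CN(C)c1ncnc2sc(Nc3ccc(Cl)cc3)nc12` reaches only a limit of the assay, > 100000 nM. Within the data shown here, the one measured step, an at least 150-fold higher number from compound 1 to compound 2 (2.20 log units; beyond the scatter), changes the group on the core and not the aryl ring, so it does not bear on the change to compound 3 `Cc1ccc(Nc2nc3c(N4CCC[C@H]4CO)ncnc3s2)cc1`: methyl in place of chloro on an aromatic carbon. Among the measured compounds shown here, with no measured step to guide it, a change within the scatter is expected, a 1.4-fold higher number from compound 1 to compound 3 (0.16 log units; within the scatter). Compound 3 is therefore estimated at 900 nM, in the range 300 nM to 3000 nM.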

Compound 3, inhibition constant: 399 nM
The estimate for compound 3 lay 2.3-fold (0.35 log units) above the measured number, and the stated range covers the measured number.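

The earlier compounds shown here said nothing about the aryl ring. In this assay, replacing 4-chlorophenyl with 4-methylphenyl gives a 1.6-fold lower number from compound 1 to compound 3 (0.20 log units; within the scatter), so at this position these two one-atom groups cannot be told apart on this read-out. No measurement shown here bears on why this swap stays within the scatter.
On these data alone, whether a methoxy group, an amine or a carboxylic acid in the same place would keep the number in this range remains open. So does the effect of having no group there at all.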